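Swapping Methyl for Bromine on the Shared Core

The compounds below may be only part of what the source reports. "The series", "measured", "known", "first", "only" and "open" are said of these compounds alone.

Compound 1 `CC(=O)O[C@@H]1OC(=O)[C@](C)(C(C)=O)[C@@H]1C` is measured in a functional assay on B16 cells (Mus musculus) for cytotoxicity, read by MTT assay (a lower number here means a stronger inhibitor, a higher number a weaker inhibitor), where compound 1 gives 4000 nM. Of the two numbers available, compound 1 has the lowest; its nearest neighbour is compound 2 `CC(=O)O[C@@H]1OC(=O)[C@](Cc2ccccc2)(C(C)=O)[C@@H]1C`, which in this assay gives 41000 nM. Going by the values given here, the one measured step, a 10-fold higher number from compound 1 to compound 2 (1.01 log units; beyond the scatter), comes from putting phenyl in place of hydrogen on a saturated chain carbon bound to a saturated ring carbon, and it weakens inhibition beyond the scatter.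

Compound 3 `CC(=O)O[C@@H]1OC(=O)[C@](Br)(C(C)=O)[C@@H]1C` has not yet been measured. Its change from compound 1 is bromo in place of methyl on a saturated ring carbon: methyl leaves and bromo enters on a saturated ring carbon of the shared core. Among the compounds with values here, the only known step describes a different kind of change at a different spot, so it bears only loosely here; it shows that the phenyl step cost inhibition, whereas in compound 3 the group that leaves and the group that enters are alike in what is counted. No step beyond the scatter is therefore expected in this assay. Compound 3 is expected to give 2500 nM, within 800 nM to 8000 nM, so the expected step is a 1.6-fold lower number from compound 1 to compound 3 (0.20 log units; within the scatter).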

Compound 3, half-maximal inhibitory concentration: 9000 nM
The estimate for compound 3 lay 3.6-fold (0.56 log units) below the measured number; the measured number lies above the stated range.
By their numbers in this assay, from the lowest: compound 1; then compound 3; then compound 2.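

In this assay, this saturated ring carbon responds even to an exchange that leaves the counted features unchanged: methyl and bromo each hold one heavy atom and neither has hydrogen-bond donors or acceptors, yet the swap gives a 2.3-fold higher number from compound 1 to compound 3 (0.35 log units; beyond the scatter) for a single atom changed. Bromo also compares with the much larger benzyl group at the same carbon, which gives a 4.6-fold lower number from compound 2 to compound 3 (0.66 log units; beyond the scatter) and places the bromo compound in the middle of the three by number, with all three separated beyond the scatter and compound 1 the strongest inhibitor of this small set. Nothing available explains why bromo gives a weaker result than methyl on this carbon.

Still open, as far as these compounds go, is whether chlorine, fluorine, a hydroxyl or an amine on this ring carbon would land closer to methyl or to bromo, and whether a longer chain such as ethyl or propyl would stay near methyl or move toward benzyl. From the compounds shown here alone, with three compounds on one cell line, it is also open whether this order would hold on other cells.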